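Swapping a lactam for a methylimidazole on the shared core

The source may report more compounds than this note shows. Statements on the series, on what has been measured and on what is new or still open speak of the compounds shown alone.

Measured so far in an assay on CHO cells for displacement of a labelled ligand from prostaglandin E2 receptor EP3 subtype (Homo sapiens), read by radioligand binding; a lower number here means a stronger inhibitor, a higher number a weaker inhibitor:
- compound 1 `CCn1ncc2c(F)cc(-c3ccc(C(CC)(CC)c4nncn4C)c(=O)[nH]3)cc21` gives 54 nM
- compound 2 `CC(C)C(c1ccc(-c2ccc3cccc(F)c3c2)[nH]c1=O)N1CCCCC1=O` gives 6.4 nM
- compound 3 `CCC(CC)(c1nnc[nH]1)c1ccc(-c2ccc3cccc(F)c3c2)[nH]c1=O` gives 19 nM

Among these three, compound 2 has the lowest number in this assay, and its gaps to compound 3 and to compound 1 both lie beyond the usual scatter, so it is the strongest inhibitor of the set. Compound 4 `Cc1c[nH]c(C(c2ccc(-c3ccc4cccc(F)c4c3)[nH]c2=O)C(C)C)n1` is the next step from compound 2. The change is 4-methyl-1H-imidazol-2-yl in place of 2-oxopiperidin-1-yl on a saturated chain carbon bound to an aromatic carbon and a saturated chain carbon. Compound 3 already shows that a five-membered aromatic ring with a hydrogen-bond donor can stand at this place of the shared core and still give a value of 19 nM in this assay, though with a different chain. Among the measured compounds shown here, no directly comparable step has been measured, so the expectation rests on that neighbour. A modest weakening from compound 2 to compound 4 is expected, a 2.3-fold higher number from compound 2 to compound 4 (0.37 log units; beyond the scatter), possibly no more than the scatter. Compound 4 is therefore estimated at 15 nM, within a range from 4 nM to 50 nM.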

Compound 4, inhibition constant: 12 nM
Beside the measured number, compound 4's estimate is 1.3-fold (0.10 log units) above it; low and high end bracket the measured number.
By their numbers in this assay, from the lowest: compounds 2, 4 and 3 (each within the scatter of the next, the first and the last beyond it); then compound 1.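

In this assay, placing 4-methyl-1H-imidazol-2-yl where 2-oxopiperidin-1-yl stood on this saturated chain carbon gives a 1.9-fold higher number from compound 2 to compound 4 (0.27 log units; within the scatter), so the two groups cannot be told apart by this measurement. Among the compounds shown here, this is the first comparison in the set that changes only one place, and it shows that a six-membered non-aromatic ring without a hydrogen-bond donor and a five-membered aromatic ring with one can both stand here with values inside the usual scatter. Nothing measured here gives a reason for this result.

As far as these compounds go, it remains open whether an imidazole without the methyl group, an amine or a carboxylic acid would fit this place equally well. Also open, from the compounds shown here alone, is whether 4-methyl-1H-imidazol-2-yl would give a similar value on a different chain.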